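The compounds below may be only part of what the source reports. "The series", "measured", "known", "first", "only" and "open" are said of these compounds alone.

Measured so far, a series on one shared core:

Compound 1, `Nc1nc(N)c2nc(O)n(Cc3ccccc3)c2n1`, gives 10 uM in a functional assay (spleen, spleen) for activation, with Mus musculus as the target; a higher number here means that more compound is needed for the effect, a lower number that less compound is needed.
Compound 2, `CCCOc1nc(N)c2nc(O)n(Cc3ccccc3)c2n1`, gives 0.01 uM in this assay.
Compound 3, `COc1nc(N)c2nc(O)n(Cc3ccccc3)c2n1`, gives 0.1 uM in this assay.

Compound 3 holds the second highest of the three numbers. Its nearest neighbour is compound 2, with a step of a 10-fold higher number from compound 2 to compound 3 (1.00 log units; beyond the scatter); the furthest is compound 1, with a step of a 100-fold lower number from compound 1 to compound 3 (2.00 log units; beyond the scatter). The step of a 1000-fold lower number from compound 1 to compound 2 (3.00 log units; beyond the scatter) spans the whole range seen.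

Compound 4, `CCCC[S+]([O-])c1nc(N)c2nc(O)n(Cc3ccccc3)c2n1`, has not yet been measured in this assay. It differs from compound 3 as follows: a group of 6 heavy atoms (4 carbon, 1 oxygen, 1 sulfur; no ring) in place of a group of 2 heavy atoms (1 carbon, 1 oxygen; no ring), on an aromatic carbon. The new group is placed on an aromatic carbon of a six-membered aromatic ring with 2 nitrogen, between two ring nitrogen atoms.

The step that bears most directly on this change is a 10-fold higher number from compound 2 to compound 3 (1.00 log units; beyond the scatter): a longer chain on this aromatic carbon goes with a lower number. For the measured compounds named here, the new group is longer than methoxy, but a sulfur takes the place of the ring-bound oxygen, and no measured step speaks to that exchange. The expected step is therefore no change at the digits printed from compound 3 to compound 4 (within the scatter), with a wide range. Compound 4 is estimated at 0.1 uM, between 0.01 uM and 1 uM.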

Compound 4, minimum effective concentration: 0.01 uM
The estimate for compound 4 lay 10-fold (1.00 log units) above the measured number; the range from low to high includes it.
By their numbers in this assay, from the lowest: compounds 2 and 4 (each within the scatter of the next); then compound 3; then compound 1.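

On the aromatic carbon between two ring nitrogen atoms, a sulfur-linked group can replace the ring-bound oxygen without loss in this assay: a 10-fold lower number from compound 3 to compound 4 (1.00 log units; beyond the scatter), and no change at the digits printed from compound 2 to compound 4 (within the scatter), so compound 4 cannot be told apart from the propoxy compound. The gain over the amino group of compound 1 therefore does not depend on an oxygen link, with a 1000-fold lower number from compound 1 to compound 4 (3.00 log units; beyond the scatter). Nothing in the data gives a reason for these steps.

Compound 4 differs from compound 3 in both the chain and the linking atoms, so the contribution of each remains unresolved. A butoxy group and a butyl chain joined through a plain sulfur would separate the two, while an amine bearing a propyl chain would test a nitrogen link.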